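Fluoro in place of acetyl: expected effect in rice

A few compounds are considered here, and "the series" means these few. Any claim that something is new, unique, unknown or untested is made for them only; others in the source may bear on it.

In an ADME assay on the whole organism with Oryza sativa as the target, tested at 1 uM (a lower number here means a stronger effect, a higher number a weaker effect of the compound at the concentration tested), compound 1 `CCOC(=O)c1cccc(NC(=O)N[C@@H](C)c2ccccc2)c1` gives 99%. Going by the values given here, compound 2 `CC(=O)c1cccc(NC(=O)N[C@@H](C)c2ccccc2)c1` gives 95%, within the scatter of compound 1; the only step between measured compounds is a number 4 percentage points lower from compound 1 to compound 2 (within the scatter). Compound 3 `C[C@H](NC(=O)Nc1cccc(F)c1)c1ccccc1` differs from compound 2 by fluoro in place of acetyl on an aromatic carbon. Among the compounds with values here, no measured step touches an aromatic carbon, so the single known step, a swap on a carbonyl carbon without effect beyond the scatter, is the only guide; a change beyond the scatter is not expected. For compound 3 a value of 95% is estimated, between 80% and 100%. The expected step is no change at the digits printed from compound 2 to compound 3 (within the scatter), within the scatter.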

Compound 3, a percentage reported as activity, at one concentration (the size of the read-out at that concentration, not a potency): 94%
Estimate against measurement, compound 3: 1 percentage points above, and the stated range covers the measured number.
By their numbers in this assay, from the lowest: compounds 3, 2 and 1 (each within the scatter of the next).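

At this aromatic carbon, meta to a large group, this assay gives a first reading: fluoro in place of acetyl gives (a number 1 percentage points lower from compound 2 to compound 3 (within the scatter)), and fluoro in place of ethoxycarbonyl gives (a number 5 percentage points lower from compound 1 to compound 3 (within the scatter)). Acetyl, ethoxycarbonyl and fluoro are therefore not told apart here, although the swap replaces a carbonyl-bearing group with a single fluorine atom. Nothing available bears on why these swaps leave the read-out within the scatter.

On these data alone, an amine, a carboxylic acid or a longer chain on this carbon remains open. So does whether any change elsewhere on the shared core moves the number beyond the scatter.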